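The compounds below may be only part of what the source reports. "The series", "measured", "known", "first", "only" and "open" are said of these compounds alone.

Working notes on the series. All compounds share one core, varied on the fused ring and on the pendant benzyl group. In a functional assay on H9c2 cells (Mus musculus) for cytotoxicity against H9c2 (Rattus norvegicus), read by MTT assay, with a stated time of 24 h (a lower number here means that less compound is needed, a higher number that more compound is needed for the effect), compound 3 `COc1ccc(Cc2coc3cccc(O)c3c2=O)cc1` gives > 100000 nM, which is a limit of the assay and not a number. Compound 1 `COc1ccc(Cc2coc3cc(O)cc(O)c3c2=O)cc1` likewise stands at a limit in this assay, > 100000 nM. Going by the values given here, compound 2 `O=c1c(Cc2ccc(C(F)(F)F)cc2)coc2cc(O)cc(O)c12` gives 12700 nM in this assay, the only numeric value so far.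

Among the compounds with values here, of the measured steps, an at least 7.8-fold lower number from compound 1 to compound 2 (0.89 log units; beyond the scatter) is the one readable step and concerns the pendant benzyl group. The other, a step that the two limits leave unreadable from compound 1 to compound 3, has both ends resting at the limit of > 100000 nM in this assay, at which 2 of the 3 values shown sit, and therefore says nothing about changes on the fused ring.

Compound 4 `COc1ccc(Cc2coc3cc(OCCCl)cc(O)c3c2=O)cc1` is not yet measured. It carries 2-chloroethoxy in place of hydrogen on an aromatic carbon. Within the data shown here, no measured step introduces a group of this kind at this place, and no measured step on the fused ring is readable, so the expectation for compound 4 can lean only on the fact that compound 3 sits at a limit in this assay. The expected step of an at least 1.4-fold lower number from compound 3 to compound 4 (0.15 log units; that floor lies within the scatter) is therefore small and uncertain, with the number for compound 4 likely to remain high. The estimate for compound 4 in this assay is 70000 nM, with a range from 15000 nM to 150000 nM, and a fair chance that only a limit is reported again.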

Compound 4, half-maximal effective concentration: > 100000 nM
Compound 4 ended at the assay's limit (the forecaster's own chance of this, stated with the estimate: 55%); middle value at least 1.4-fold (0.15 log units) away from the limit.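

The steps from compound 1 and from compound 3 to compound 4 cannot be read in this assay, because both ends of each step rest at a limit and not at a number: the limit of > 100000 nM in this assay, at which 3 of the 4 values shown sit.

The compounds shown leave open whether 2-chloroethoxy, or any other change on the fused ring, moves the number in this assay at all.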